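The source may hold more compounds than are shown below. What is called first, only, known or untested is meant among the compounds shown, and "the series" means these compounds.

Measured so far:
- compound 1 `Nc1ccc(-c2cc(-c3ccc(C(F)(F)F)cc3)n[nH]2)cc1` — 21500 nM
- compound 2 `COc1ccccc1-c1cc(-c2ccccc2-c2ccccc2)n[nH]1` — 9100 nM

Both were run in a functional assay on NCI-H460 cells (Homo sapiens) for inhibition, read by MTT assay, with a stated time of 48 h; on this read-out higher numbers stand for weaker inhibition of growth and lower numbers for stronger inhibition of growth. Compound 2 holds the lower of the two numbers, and its gap to compound 1 is beyond the usual scatter, so compound 2 is the stronger grower-inhibitor of the pair. The two compounds differ in more than one place, so nothing is said here about which part of the change carries that gap.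

Compound 3 `Oc1ccc(-c2cc(-c3ccccc3-c3ccccc3)n[nH]2)cc1` has not been measured. It differs from compound 2 in one place: 4-hydroxyphenyl in place of 2-methoxyphenyl on an aromatic carbon. Among the measured compounds shown here, no measured pair isolates this particular exchange, so its effect is unknown. For compound 3 the expectation is a step from compound 2 of a 1.1-fold higher number from compound 2 to compound 3 (0.04 log units; within the scatter) in this assay, that is, no change clearly beyond the scatter in either direction. Compound 3 is thus estimated at 10000 nM, within a range of 3500 nM to 30000 nM.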

Compound 3, concentration for 50% growth inhibition: 6900 nM
Compound 3: middle estimate off by 1.4-fold (0.16 log units), on the high side, within the range that was stated.
By their numbers in this assay, from the lowest: compounds 3 and 2 (each within the scatter of the next); then compound 1.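

In this assay, the first exchange read at this position, on an aromatic carbon next to the ring nitrogen, gives a 1.3-fold lower number from compound 2 to compound 3 (0.12 log units; within the scatter), so replacing 2-methoxyphenyl with 4-hydroxyphenyl leaves the number within the scatter. Here the entering group carries a hydrogen-bond donor that the leaving group lacks, and that difference comes with no step beyond the scatter in this pair. The data offer no measurement that explains this outcome.

The two groups differ both in the oxygen substituent and in where it sits on the phenyl ring, so this single step cannot separate those two changes; 4-methoxyphenyl and 2-hydroxyphenyl at this place would do so. Going by these compounds, how a carboxylic acid or a longer alkoxy chain on this phenyl ring would read also remains open.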